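From Benzyl to Hydroxybutyl on the Shared Core

A few compounds are considered here, and "the series" means these few. Any claim that something is new, unique, unknown or untested is made for them only; others in the source may bear on it.

Measured so far in a functional assay on RAW264.7 cells (Mus musculus), with a stated time of 3 days; a lower number here means a stronger inhibitor, a higher number a weaker inhibitor:
compound 1, `COc1cnc(-c2ccccn2)nc1N1CCCCCC1`, gives 690 nM
compound 2, `COc1cnc(-c2ccccn2)nc1NCc1ccccc1`, gives 420 nM

Compound 2 holds the lowest of these two numbers, but compound 1 sits within the usual scatter of it, so no order between the two can be read from the values. For the measured compounds named here, no pair of measured compounds differs in a single place, so there is no measured step to lean on.

Compound 3, `COc1cnc(-c2ccccn2)nc1NCCCCO`, differs from compound 2 in one place: 3-hydroxypropyl in place of phenyl on a saturated chain carbon bound to a nitrogen on an aromatic ring. The change removes a ring and brings in a chain; nothing measured here shows how such a swap behaves on this core. The authors nonetheless expect a weaker inhibitor, a step of a 3.1-fold higher number from compound 2 to compound 3 (0.49 log units; beyond the scatter) in this assay, somewhat beyond the scatter. For compound 3 the expected value is 1300 nM, with a range from 400 nM to 4500 nM.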

Compound 3, half-maximal inhibitory concentration: 3000 nM
Beside the measured number, compound 3's estimate is 2.3-fold (0.36 log units) below it; low and high end bracket the measured number.
By their numbers in this assay, from the lowest: compounds 2 and 1 (each within the scatter of the next); then compound 3.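

In this assay, for the compounds shown here, the earlier pair could not show whether this position responds to change, but it does: 4-hydroxybutyl in place of benzyl gives a 7.1-fold higher number from compound 2 to compound 3 (0.85 log units; beyond the scatter) and is the first step here beyond the scatter. The same compound also stands apart from the azepane compound, as (4-hydroxybutyl)amino in place of azepan-1-yl on an aromatic carbon gives a 4.3-fold higher number from compound 1 to compound 3 (0.64 log units; beyond the scatter), so the weaker number holds against both neighbours. Nothing at hand says what lies behind these steps.

The change removes the phenyl ring and brings in the hydroxyl together, so the compounds shown cannot separate the two. Going by these compounds, how a plain butyl chain, a 4-aminobutyl chain or a benzyl group carrying a hydroxyl would fare on the shared core remains open.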